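A few compounds are considered here, and "the series" means these few. Any claim that something is new, unique, unknown or untested is made for them only; others in the source may bear on it.

In a functional assay on DU-145 cells (Homo sapiens) for inhibition, read by trypan blue exclusion, with a stated time of 96 h (on this read-out higher numbers stand for weaker inhibition of growth and lower numbers for stronger inhibition of growth), the measured compounds stand as follows:

Compound 1 `Cc1ccc(/C=C(\C(=O)c2ccc([N+](=O)[O-])cc2)S(=O)(=O)Cc2ccc(Cl)cc2)s1` gives 25000 nM
Compound 2 `CCOc1ccc(/C=C(/Sc2ccccc2Cl)C(=O)c2ccc(Cl)cc2)cc1OC` gives 50000 nM

Compound 2, at 50000 nM, lies within the usual scatter of compound 1, at 25000 nM, so these two values cannot be told apart.

Compound 3 `CCOc1ccc(/C=C(/SCc2ccc(C)cc2)C(=O)c2ccc(Cl)cc2)cc1OC` has not been measured yet. It keeps the shared core of compound 2 and differs in one place: 4-methylbenzyl in place of 2-chlorophenyl on a sulfur. In words, this is 4-methylbenzyl in place of 2-chlorophenyl on a sulfur. Each of the two groups holds one six-membered aromatic ring of carbon only.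

For the measured compounds named here, no measured pair shows what this swap does in this assay, so there is no direct guide. The only hint is indirect: compound 1 at 25000 nM and compound 2 at 50000 nM differ in more than one place, yet their values sit within the scatter. A change beyond the scatter is therefore not expected, and no firm direction can be given. The expected step of a 1.4-fold lower number from compound 2 to compound 3 (0.15 log units; within the scatter) is correspondingly small. For compound 3 the estimated value is 35000 nM, with an expected range from 10000 nM to 100000 nM.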

Compound 3, concentration for 50% growth inhibition: 25000 nM
Compound 3: the middle estimate sits 1.4-fold (0.15 log units) above what was measured; low and high end bracket the measured number.
By their numbers in this assay, from the lowest: compounds 1, 3 and 2 (each within the scatter of the next).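

For the compounds shown here, this is the first direct reading of a change at this sulfur: in this assay, 4-methylbenzyl in place of 2-chlorophenyl gives a 2.0-fold lower number from compound 2 to compound 3 (0.30 log units; within the scatter) and so compound 2 and compound 3 cannot be told apart. The swap removes the chlorine, adds a methyl and places a carbon between the sulfur and the aromatic ring, yet none of this together produces a step beyond the scatter, so this pair gives no sign that the choice between these two groups matters for the read-out. No measurement is available that could explain the result or say whether the individual changes matter on their own.

Since several features change in this one swap, a plain benzyl or a 4-methylphenyl group on the same sulfur would be needed to tell whether opposing effects of the separate changes are hidden within this result. From the compounds shown here alone, both groups also hold one six-membered aromatic ring of carbon only, so it remains open how the value would respond to an amine, a carboxylic acid or a simple longer carbon chain at this sulfur.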